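A few compounds are considered here, and "the series" means these few. Any claim that something is new, unique, unknown or untested is made for them only; others in the source may bear on it.

In a functional assay on NCI-H460 cells (Homo sapiens) for inhibition, read by MTT assay, with a stated time of 24 h, tested at 1 ug/mL (a lower number here means less inhibition of growth, a higher number more inhibition of growth at the concentration tested), compound 1, with the structure `O=C(CCCCC1CCSS1)Nc1ccccn1`, gives 0.81%. Compound 2, `O=C(CCCCC1CCSS1)Nc1ccc(Cl)cn1`, differs from it only by the change (chloro in place of hydrogen on an aromatic carbon), and in this assay compound 2 gives 6.26%; the step of a number 5.5 percentage points higher from compound 1 to compound 2 (within the scatter). Compound 3, `O=C(CCCCC(S)CCS)Nc1ccccc1`, carries a different core; how its core differs from that of compound 1 is not broken down here. In this assay compound 3 gives 4.3%, which lies close to the values of compound 1 and compound 2.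

Compound 4, `O=C(CCCCC(S)CCS)Nc1ccc(Cl)cc1`, has not yet been measured. It differs from compound 3 by chloro in place of hydrogen on an aromatic carbon. This is the same kind of change as that from compound 1 to compound 2, but the surroundings differ: in compound 2 the chloro sits on a six-membered aromatic ring with 1 nitrogen, two atoms from the ring nitrogen, whereas in compound 4 it sits on a six-membered aromatic ring of carbon only.

Within the data shown here, since the only measured example of this kind of change, a number 5.5 percentage points higher from compound 1 to compound 2 (within the scatter), stayed within the scatter, the expected step for compound 4 is likewise small, a number 3.7 percentage points higher from compound 3 to compound 4 (within the scatter). Compound 4 is therefore estimated at 8% in this assay, between 0% and 18%.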

Compound 4, percent growth inhibition at one concentration: 6.76%
Compound 4: the middle estimate sits 1.2 percentage points above what was measured, within the range that was stated.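

In this assay, chloro in place of hydrogen on the aromatic carbon gives a number 2.5 percentage points higher from compound 3 to compound 4 (within the scatter). Set beside the earlier case, the two steps cannot be told apart: the same change on two cores in this assay, a number 5.5 percentage points higher (within the scatter) from compound 1 to compound 2 and a number 2.5 percentage points higher (within the scatter) from compound 3 to compound 4, 3 percentage points apart, within the scatter of two such steps. So the change gives no sign of behaving differently on the two cores, but this does not show that it carries over as a real effect: both steps lie within the scatter, so neither can be told from no step at all, and the comparison rests on just two pairs tested at a single concentration.

The compounds shown leave open whether another group on the aromatic ring, such as methoxy or an amine, or a longer chain in place of the one in these compounds, would shift the growth inhibition beyond the scatter. They also leave open how the chloro pairs would compare at a different concentration, where the numbers might be large enough to separate.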